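Sulfonamide series: aryl swap on the sulfonyl sulfur

The compounds below may be only part of what the source reports. "The series", "measured", "known", "first", "only" and "open" are said of these compounds alone.

Measured compounds:
- compound 1 `CCCCc1ccc(S(=O)(=O)NCCCCCCNCc2ccc(Br)cc2)cc1`: 5700 nM
- compound 2 `O=S(=O)(NCCCCNCc1ccc(Br)cc1)c1cc(C(F)(F)F)cc(C(F)(F)F)c1`: 2100 nM
- compound 3 `CC(C)c1ccc(S(=O)(=O)NCCCCCCNCc2ccc(Br)cc2)cc1`: 5730 nM

In a functional assay on MIA PaCa-2 cells (Homo sapiens) for inhibition, read by MTT assay, with a stated time of 72 h (on this read-out lower numbers stand for stronger inhibition of growth and higher numbers for weaker inhibition of growth), compound 3 gives 5730 nM, the highest of the three numbers. Its nearest neighbour is compound 1, where the move is a 1.0-fold higher number from compound 1 to compound 3 (0.00 log units; within the scatter); the furthest is compound 2, whose value of 2100 nM sits beyond the scatter from compound 3. Within the data shown here, compound 2 differs from compound 3 in more than one place, so no single step is drawn between them.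

Compound 4 `O=S(=O)(NCCCCCCNCc1ccc(Br)cc1)c1cc(Cl)cc(Cl)c1` is not yet measured in this assay. It differs from compound 3 by 3,5-dichlorophenyl in place of 4-isopropylphenyl on a sulfonyl sulfur. Among the measured compounds shown here, the only single-point step in the set, from compound 1 to compound 3, concerns an exchange of one alkyl group for another on the aryl ring and is flat; it gives no guide to replacing the whole aryl group. The lower number for compound 2, which also carries a ring bearing two substituents in the 3 and 5 positions on the sulfonyl sulfur but on a different linker, is the only hint that such a change might move the number downward.

Compound 4 is therefore expected to land at 3200 nM (range 1300 nM to 8000 nM), a step of a 1.8-fold lower number from compound 3 to compound 4 (0.25 log units; within the scatter) that is uncertain in size and may fall within the scatter.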

Compound 4, concentration for 50% growth inhibition: 12000 nM
Estimate against measurement, compound 4: 3.8-fold (0.57 log units) below, outside the stated range (above it).
By their numbers in this assay, from the lowest: compound 2; then compounds 1 and 3 (each within the scatter of the next); then compound 4.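

In this assay, the aryl group on the sulfonyl sulfur affects the read-out more than the earlier alkyl exchange did: the latter gave a 1.0-fold higher number from compound 1 to compound 3 (0.00 log units; within the scatter), whereas the full aryl swap gives a 2.1-fold higher number from compound 3 to compound 4 (0.32 log units; beyond the scatter). The step is modest, but it shows that with the chain of compound 3 held constant, 3,5-dichlorophenyl in place of 4-isopropylphenyl gives weaker inhibition of growth, so this position is not insensitive to every change. No measured data explain this step.

Compound 2 differs from compound 4 in more than one place, so the effects of its aryl group and its shorter chain remain unseparated, and the compounds shown do not reveal whether the step from 4-isopropylphenyl to 3,5-dichlorophenyl would keep its direction or size on that shorter chain. Also open, going by these compounds, is how this position responds to a methoxy group, an amine or a carboxylic acid on the aryl ring, or to a pyridine ring in place of the benzene ring.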